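The source may hold more compounds than are shown below. What is called first, only, known or untested is meant among the compounds shown, and "the series" means these compounds.

In an ADME assay on MT4 cells (Homo sapiens) for cytotoxicity, read by MTT assay, with a stated time of 96 h (on this read-out lower numbers stand for higher toxicity in this test and higher numbers for lower toxicity in this test), compound 1 (`Cc1ccc(-c2nn(-c3ccccc3)cc2CNc2ccc(Br)cc2)cc1`) gives > 100000 nM, which is a limit of the assay and not a number. Compound 2 (`Brc1ccc(NCc2cn(-c3ccccc3)nc2-c2ccc(Br)cc2)cc1`) gives > 100000 nM, which is likewise only a limit. Compound 2 therefore stands at the limit of > 100000 nM in this assay, at which 2 of the 2 values shown sit. Compound 3 (`FC(F)(F)c1ccc(-c2nn(-c3ccccc3)cc2CNc2ccc(Br)cc2)cc1`) differs from it by trifluoromethyl in place of bromo on an aromatic carbon, with trifluoromethyl in place of bromo on an aromatic carbon, para to a large group. Among the compounds with values here, only one measured step bears on this change: a step that the two limits leave unreadable from compound 1 to compound 2, with bromo in place of methyl at the same kind of carbon. It gives no size to carry over, but neither measured compound gave a number in this assay. The expected outcome is therefore no change beyond the scatter, and the estimated move is a number no higher from compound 2 to compound 3 (the limit leaves the size open). For compound 3 the expected value is 100000 nM, within an estimated range of 40000 nM to 150000 nM, and it may well be reported only as a limit.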

Compound 3, half-maximal cytotoxic concentration: > 100000 nM
Compound 3: only a limit was reported; the forecaster's own chance of this, stated with the estimate: 85%; the middle value sits exactly at the limit.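

Compound 1, compound 2 and compound 3 all sit at a limit, so no step among them can be read: the limit of > 100000 nM in this assay, at which 3 of the 3 values shown sit.

The compounds shown leave open whether methyl, bromo and trifluoromethyl at this place differ at all in this assay, and at what concentration any of the three becomes toxic.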